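Carboxythiophene replaces a nitrile chain: solubility estimate ahead

The source may hold more compounds than are shown below. What is called first, only, known or untested is meant among the compounds shown, and "the series" means these compounds.

Compound 1 `CC(C)c1ncc2c(N)c(C#N)c(N)nc2n1`: > 1000000 nM in a physicochemical assay for solubility, in phosphate buffer, with a stated time of 18 h (a higher number here means a more soluble compound, a lower number a less soluble compound), a limit of the assay rather than a number.
Compound 2 `CC(C)(C)c1nc(CCCCC#N)c2c(N)c(C#N)c(N)nc2n1`: 16000 nM in this assay.

For the measured compounds named here, compound 2 holds the only numerical value in this assay; the other entry is a limit, as noted in the limit of > 1000000 nM in this assay, at which 1 of the 2 values shown sits. Compound 3 `CC(C)(C)c1nc(-c2ccc(C(=O)O)s2)c2c(N)c(C#N)c(N)nc2n1` has not yet been measured in this assay. It differs from compound 2 in one place: 5-carboxythiophen-2-yl in place of 4-cyanobutyl on an aromatic carbon. Going by the values given here, no step between two measured compounds is available to anchor the expectation. Even so, the change from a 4-cyanobutyl chain to a 5-carboxythiophen-2-yl group is expected to raise solubility beyond the usual scatter, with the step from compound 2 to compound 3 estimated at a 9.4-fold higher number from compound 2 to compound 3 (0.97 log units; beyond the scatter). Compound 3 is therefore estimated at 150000 nM in this assay, with a range from 20000 nM to 1000000 nM; a reading that reaches the limit of the assay, as compound 1 did, cannot be ruled out.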

Compound 3, solubility: > 1000000 nM
Compound 3 ended at the assay's limit; the forecaster's own chance of this, stated with the estimate: 20%; middle value at least 6.6-fold (0.82 log units) away from the limit.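

In this assay, for the compounds shown here, the place next to the ring nitrogen proved sensitive to the group it carries: 5-carboxythiophen-2-yl in place of 4-cyanobutyl gives an at least 62-fold higher number from compound 2 to compound 3 (1.79 log units; beyond the scatter), a large step and the only one here between compounds that differ in one place. Compound 1 and compound 2 differ in more than one place, so they could not show this. The reading of > 1000000 nM for compound 3 is a limit of the assay and not a number, so the step gives only a lower bound on the change: the limit of > 1000000 nM in this assay, at which 2 of the 3 values shown sit.

The change replaces the chain with a ring and brings in the carboxylic acid in one step, so the compounds shown do not separate the two. An unsubstituted thiophen-2-yl group, or a carboxylic acid carried on an open chain, would bear on that question.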